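A few compounds are considered here, and "the series" means these few. Any claim that something is new, unique, unknown or untested is made for them only; others in the source may bear on it.

Two compounds that share one core and differ only in the chain carried on the amine nitrogen have been measured. Compound 1 `COc1cc(CN(CCCO)Cc2ccc(O)c(OC)c2)ccc1O` carries a chain ending in a hydroxy group, and in a functional assay, with a stated time of 30 min (a higher number here means a weaker inhibitor, a lower number a stronger inhibitor), compound 1 gives 13700 nM. Compound 2 `COc1cc(CN(CCCCO)Cc2ccc(O)c(OC)c2)ccc1O` carries a chain one carbon longer, and in this assay compound 2 gives 21000 nM. Among the compounds with values here, the single measured step runs a 1.5-fold higher number from compound 1 to compound 2 (0.19 log units; within the scatter). Among these two numbers compound 2 stands highest, yet its gap to compound 1 lies within the scatter, so the two cannot truly be ordered.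

Compound 3 `COc1cc(CN(CCCCCO)Cc2ccc(O)c(OC)c2)ccc1O` lengthens the same chain once more: hydroxymethyl in place of hydroxy on a saturated chain carbon, four bonds along the chain from an amine nitrogen. Within the data shown here, the one step that bears on this change, the earlier lengthening of the chain, was small, so for compound 3 no step beyond the scatter is expected in this assay, at most a slight drift toward a higher number. The change is expected to amount to a 1.2-fold higher number from compound 2 to compound 3 (0.09 log units; within the scatter). Compound 3 is therefore estimated at 26000 nM, with a range from 11000 nM to 60000 nM.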

Compound 3, half-maximal inhibitory concentration: 24000 nM
Beside the measured number, compound 3's estimate is 1.1-fold (0.03 log units) above it; the range from low to high includes it.
By their numbers in this assay, from the lowest: compounds 1, 2 and 3 (each within the scatter of the next).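

In this assay, one more carbon at this place, four bonds along the chain from an amine nitrogen, gives a 1.1-fold higher number from compound 2 to compound 3 (0.06 log units; within the scatter) and so no change that can be told from repeat-measurement noise. The wider comparison gives a 1.8-fold higher number from compound 1 to compound 3 (0.24 log units; within the scatter) and shows that even two added carbons taken together stay inside the scatter. Within the data shown here, the earlier pair offered only a single small step, whereas all three compounds now sit within the scatter of one another, so across these chains ending in a hydroxy group the numbers cannot be put in order and no real trend with chain length can be claimed.

Nothing in the data at hand offers an explanation for this flat result. Still open, going by these compounds, is whether a longer chain, or an amine or a carboxylic acid in place of the hydroxy group at the chain end, would move the number beyond the scatter.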